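This account rests on a few compounds, and the source may have more. Where it says the series, first, only, none or still open, it means among the compounds named here.

In an ADME assay on MDBK cells (Bos taurus) for cytotoxicity (a higher number here means that more compound is tolerated, a lower number that less compound is tolerated), so far:
- Compound 1 (`N#Cc1ccc(Cn2ccc3nc(-c4ccccc4)nc-3c2)cc1`) gives > 100000 nM as a limit of the assay, not a number
- Compound 2 (`Clc1ccc(Cn2ccc3nc(-c4ccccc4)nc-3c2)cc1Cl`) gives 71000 nM as a measured number

Among the measured compounds shown here, compound 2 holds the only true number here, so it cannot yet be ranked against anything. For compound 1 the read-out is the limit of > 100000 nM in this assay, at which 1 of the 2 values shown sits, and no number.

Compound 3 (`c1ccc(CCCn2ccc3nc(-c4ccccc4)nc-3c2)cc1`) differs from compound 2 in one place, on a saturated chain carbon bound to an aromatic nitrogen (phenethyl in place of 3,4-dichlorophenyl on a saturated chain carbon bound to an aromatic nitrogen), where phenethyl stands in place of 3,4-dichlorophenyl. Both groups hold one six-membered aromatic ring of carbon only, and the chlorine leaves.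

For the measured compounds named here, one measured step touches this same place: an at least 1.4-fold lower number from compound 1 to compound 2 (0.14 log units; that floor lies within the scatter) with 3,4-dichlorophenyl replacing 4-cyanophenyl. That step gives only a floor, and the floor stays within the scatter, so it shows no real change from swapping the group at this place.

The expected result is therefore a 1.0-fold lower number from compound 2 to compound 3 (0.01 log units; within the scatter) in this assay with no shift beyond the scatter anticipated. The estimated value for compound 3 is 70000 nM with an expected range from 30000 nM to 100000 nM around it.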

Compound 3, half-maximal cytotoxic concentration: > 100000 nM
Compound 3: only a limit was reported; the forecaster's own chance of this, stated with the estimate: 30%; at least 1.4-fold (0.15 log units) between middle value and limit.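

In this assay, putting phenethyl in place of 3,4-dichlorophenyl on a saturated chain carbon bound to an aromatic nitrogen gives an at least 1.4-fold higher number from compound 2 to compound 3 (0.14 log units; that floor lies within the scatter), so a second swap at this place, this time one in which the chlorine leaves, also yields only a floor inside the scatter and no real change. Compound 3 gives > 100000 nM, which is a limit of the assay and not a number, and the step between compound 1 and compound 3 cannot be read, as both values are limits. What is new is that three different groups at this place now show no difference beyond the scatter, with the read-out mostly stuck at the top of the assay's range: the limit of > 100000 nM in this assay, at which 2 of the 3 values shown sit.

Whether any group at this place can push the tolerated concentration clearly below that of compound 2 remains open, as does how much room lies beyond the limit for the groups already shown. An amine or a carboxylic acid on the ring of this side group, or a longer chain between that ring and the core, would be the next groups to set against these.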